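A few compounds are considered here, and "the series" means these few. Any claim that something is new, unique, unknown or untested is made for them only; others in the source may bear on it.

In an in vitro ADME assay on microsomes from liver (Rattus norvegicus) for metabolic stability (on this read-out higher numbers stand for fast clearance and lower numbers for slow clearance), compound 2 `CC[C@H](C)[C@@H]1C(=O)N[C@H](C2Cc3ccccc3C2)C(=O)N1[C@@H](C(=O)N(C)C)c1ccc(C)[n+]([O-])c1` gives 1 mL.min-1.g-1, level with compound 1 `CC[C@H](C)[C@@H]1C(=O)N[C@H](C2Cc3ccccc3C2)C(=O)N1[C@@H](C(=O)N(C)C)c1ccc(C)nc1C` at 1 mL.min-1.g-1. Compound 3 `CC[C@H](C)[C@@H]1C(=O)N[C@H](C2Cc3ccccc3C2)C(=O)N1[C@@H](C(=O)N(C)C)c1cnc(C)cc1C` keeps the shared core and differs from compound 2 in one group: a group of 8 heavy atoms (7 carbon, 1 nitrogen; one six-membered aromatic ring with 1 hetero atom) in place of a group of 8 heavy atoms (6 carbon, 1 nitrogen, 1 oxygen; one six-membered aromatic ring with 1 hetero atom), on a saturated chain carbon bound to an amide-type nitrogen in a ring and a carbonyl carbon. The entering group is 4,6-dimethylpyridin-3-yl. Among the measured compounds shown here, only one measured step bears on this change, as it alters the group at the same place: no change at the digits printed from compound 1 to compound 2 (within the scatter). That single step stayed within the scatter, so no shift beyond the scatter is expected in this assay. The expected step is no change at the digits printed from compound 2 to compound 3 (within the scatter). For compound 3, the estimated clearance is 1 mL.min-1.g-1, within an expected range of 0.5 mL.min-1.g-1 to 3 mL.min-1.g-1.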

Compound 3, intrinsic clearance in microsomes: 1 mL.min-1.g-1
Beside the measured number, compound 3's estimate shows no gap at the digits printed; the range from low to high includes it.
By their numbers in this assay, from the lowest: compounds 1, 2 and 3 (each within the scatter of the next).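

On the saturated chain carbon bound to an amide-type nitrogen in a ring and a carbonyl carbon, 4,6-dimethylpyridin-3-yl in place of 2,6-dimethylpyridin-3-yl gives no change at the digits printed from compound 1 to compound 3 (within the scatter) in this assay and so is not told apart from it by this read-out. Replacing the oxygen-bearing group with 4,6-dimethylpyridin-3-yl gives no change at the digits printed from compound 2 to compound 3 (within the scatter) as well. All three groups at this place now lie within the scatter of one another. From the compounds shown here alone, whether a pyridine ring carrying a carboxylic acid or an amine would match them stays open. Nothing measured here explains these matching values.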